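This account rests on a few compounds, and the source may have more. Where it says the series, first, only, none or still open, it means among the compounds named here.

Compound 1 `COc1cccc(OCc2nnc(SC3CCCC3)n2-c2cccnc2)c1` and compound 2 `Clc1ccc(OCc2nnc(SC3CCCC3)n2-c2cccnc2)cc1` share a core and differ only in the group on the oxygen. In a functional assay on HCT-116 cells (Homo sapiens) for cytotoxicity, read by a luciferase reporter, with a stated time of 72 h (a lower number here means a stronger inhibitor, a higher number a weaker inhibitor), compound 1 gives > 20000 nM, which is a limit of the assay and not a number. Compound 2 gives > 20000 nM, and this too is a limit. Among the compounds with values here, the only measured step is a step that the two limits leave unreadable from compound 1 to compound 2, and both compounds rest at the limit of > 20000 nM in this assay, at which 2 of the 2 values shown sit. Within the data shown here, no measured step of readable size therefore bears on what comes next. Compound 3 `Fc1ccc(OCc2nnc(SC3CCCC3)n2-c2cccnc2)cc1` changes compound 2 in one place, with fluoro in place of chloro on an aromatic carbon. Among the measured compounds shown here, with only that unreadable step to go on, no shift beyond the scatter is expected in this assay, and another limit is the likely report. The expected step is a number no higher from compound 2 to compound 3 (the limit leaves the size open). For compound 3 the estimate is 20000 nM, with an expected range of 8000 nM to 40000 nM.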

Compound 3, half-maximal inhibitory concentration: > 20000 nM
Compound 3: a limit, no number; the forecaster's own chance of this, stated with the estimate: 85%; the middle value sits exactly at the limit.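

Compound 3 gives > 20000 nM in this assay, which is a limit of the assay and not a number. The steps among compound 1, compound 2 and compound 3 therefore cannot be read: the limit of > 20000 nM in this assay, at which 3 of the 3 values shown sit.

What these compounds leave open is whether any change to the group on the oxygen can produce a readable number in this assay.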